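The source may hold more compounds than are shown below. What is called first, only, known or untested is meant among the compounds shown, and "the series" means these compounds.

Of the compounds shown here, two built on one shared core have been tested so far in a functional assay on A549 cells (Homo sapiens) for inhibition, read by MTT assay, with a stated time of 48 h; a lower number here means a stronger inhibitor, a higher number a weaker inhibitor. Compound 1 `COc1cc(-c2nccn3cc(-c4ccc([N+](=O)[O-])cc4)nc23)cc(OC)c1OC`, which carries a nitro group on an aromatic carbon, gives > 10000 nM, a limit of the assay and not a number. Compound 2 `COc1cc(-c2nccn3cc(-c4ccc(O)cc4)nc23)cc(OC)c1OC`, with hydroxy in place of nitro, gives > 10000 nM, which is again a limit. Compound 2 therefore offers no exact potency and stands with compound 1 at the limit of > 10000 nM in this assay, at which 2 of the 2 values shown sit. Among the measured compounds shown here, the only measured change is a step that the two limits leave unreadable from compound 1 to compound 2, so it supplies neither a size nor a direction to carry forward.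

Compound 3 `COc1cc(-c2nccn3cc(-c4ccc(C)cc4)nc23)cc(OC)c1OC` makes one further swap, 4-hydroxyphenyl to 4-methylphenyl: methyl in place of hydroxy on an aromatic carbon. For the measured compounds named here, with the limit of > 10000 nM in this assay, at which 2 of the 2 values shown sit, as the only guide, no clear gain in this assay is expected, and the assay may well report only a limit again. The expected change, an estimate with wide uncertainty, is a step that the limit leaves unreadable from compound 2 to compound 3. For compound 3 the estimated half-maximal inhibitory concentration is 15000 nM, with an expected range from 4000 nM to 50000 nM.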

Compound 3, half-maximal inhibitory concentration: 135 nM
Beside the measured number, compound 3's estimate is 110-fold (2.05 log units) above it; the measured number lies below the stated range.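

At this position, on an aromatic carbon para to a large group, the choice of substituent can separate a limit from an exact potency on the shared core. In this assay, methyl in place of hydroxy gives an at least 74-fold lower number from compound 2 to compound 3 (1.86 log units; beyond the scatter), and methyl in place of nitro gives an at least 74-fold lower number from compound 1 to compound 3 (1.86 log units; beyond the scatter), whereas the step between the two earlier compounds cannot be read. Compound 3 is the only one of the three with an exact value, and both large steps are measured from a limit, so they set a minimum size: the limit of > 10000 nM in this assay, at which 2 of the 3 values shown sit.

The compounds shown cannot separate a benefit specific to methyl from a penalty shared by hydroxy and nitro, and the hydroxy-to-methyl swap alone does not explain the gain, even though hydroxy brings a hydrogen-bond donor and acceptor that methyl lacks. Going by these compounds, it also remains open how far the gain extends to other groups at this position, such as ethyl, a longer chain, chlorine or an amine, and whether activity would hold, rise or fall back to a limit with them.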